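The source may report more compounds than this note shows. Statements on the series, on what has been measured and on what is new or still open speak of the compounds shown alone.

Three compounds share one core and differ only in the aromatic group attached to the amide carbonyl. Compound 1 `Cc1ccc(C(=O)Nc2cccc(-c3oc4cc(-c5ccc(F)cc5)ccc4c(=O)c3O)c2)cc1` gives 6190 nM in a functional assay on HeLa cells (Homo sapiens) for antiproliferative activity, read by CCK-8 assay, with a stated time of 72 h (on this read-out higher numbers stand for weaker inhibition and lower numbers for stronger inhibition), compound 2 `O=C(Nc1cccc(-c2oc3cc(-c4ccc(F)cc4)ccc3c(=O)c2O)c1)c1ccc(Cl)cc1` gives 3670 nM, and compound 3 `Cc1ccccc1C(=O)Nc1cccc(-c2oc3cc(-c4ccc(F)cc4)ccc3c(=O)c2O)c1` gives 11900 nM, the highest of the three numbers. The step of a 1.9-fold higher number from compound 1 to compound 3 (0.28 log units; within the scatter) lies within the scatter, while a 3.2-fold higher number from compound 2 to compound 3 (0.51 log units; beyond the scatter) is a modest step beyond it. Compound 4 `CCc1ccc(C(=O)Nc2cccc(-c3oc4cc(-c5ccc(F)cc5)ccc4c(=O)c3O)c2)cc1` carries 4-ethylphenyl in place of 2-methylphenyl on a carbonyl carbon. Both measured steps ending at compound 3 ran toward a higher number, so the return to a 4-substituted phenyl of the kind seen in compound 1 is expected to give a lower number, with a 2.2-fold lower number from compound 3 to compound 4 (0.34 log units; beyond the scatter) as the estimated step. For compound 4 the expected value in this assay is 5500 nM, within a range from 2500 nM to 12000 nM.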

Compound 4, half-maximal inhibitory concentration: 21000 nM
Compound 4: the middle estimate sits 3.8-fold (0.58 log units) below what was measured; measured number outside the range, above it.
By their numbers in this assay, from the lowest: compounds 2, 1, 3 and 4 (each within the scatter of the next, the first and the last beyond it).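

At this place on the carbonyl carbon, a 4-substituted phenyl does not by itself bring a lower number in this assay: 4-ethylphenyl in place of 2-methylphenyl gives a 1.8-fold higher number from compound 3 to compound 4 (0.25 log units; within the scatter). Small changes to the 4-substituent count, since methyl in place of hydrogen on the chain carbon gives a 3.4-fold higher number from compound 1 to compound 4 (0.53 log units; beyond the scatter), and ethyl in place of chloro gives a 5.7-fold higher number from compound 2 to compound 4 (0.76 log units; beyond the scatter). Nothing measured here explains these steps. Going by these compounds, whether a longer chain such as propyl raises the number further remains open, as does the effect of an amine or a methoxy group at the same place on the phenyl.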